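A Selenium-Bearing Chain Replaces Bromine on Compound 3

The source may hold more compounds than are shown below. What is called first, only, known or untested is meant among the compounds shown, and "the series" means these compounds.

Values in a functional assay on HCT-116 cells (Homo sapiens) for antiproliferative activity, read by MTT assay, with a stated time of 48 h (a lower number here means a stronger inhibitor, a higher number a weaker inhibitor), for the three measured compounds:
compound 1 `COc1ccc(N(C)c2ccnc(Cl)n2)cc1F` gives 914 nM
compound 2 `COc1ccc(N(C)c2ccnc(Cl)n2)cc1[N+](=O)[O-]` gives 4700 nM
compound 3 `COc1ccc(N(C)c2ccnc(Cl)n2)cc1OCCCBr` gives 1970 nM

Compound 3 holds the second highest of these three numbers. Two modest measured steps frame it: a 2.2-fold higher number from compound 1 to compound 3 (0.33 log units; beyond the scatter) and, on the other side, a 2.4-fold lower number from compound 2 to compound 3 (0.38 log units; beyond the scatter) in the same read-out. The change to compound 4 `COc1ccc(N(C)c2ccnc(Cl)n2)cc1OCCCCC[Se]C#N` is a group of 5 heavy atoms (3 carbon, 1 nitrogen, 1 selenium; no ring) in place of one bromine atom, on a saturated chain carbon, three bonds along the chain from an oxygen on an aromatic ring and the rest of the molecule stays the same. Among the measured compounds shown here, no measured step touches this site, since all three alter the substituent on the aromatic carbon. The largest of them is a 5.1-fold higher number from compound 1 to compound 2 (0.71 log units; beyond the scatter) and that is still modest. These steps therefore limit the expected size only loosely and give no direction. A modest step is expected, and the estimate leans lower, toward compound 1 at 914 nM without the data settling it. The estimated step is a 2.5-fold lower number from compound 3 to compound 4 (0.39 log units; beyond the scatter) and it remains only an expectation. Compound 4 is estimated at 800 nM within a range from 150 nM to 3000 nM as its expected spread.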

Compound 4, half-maximal inhibitory concentration: > 10000 nM
Compound 4: a limit, no number (the forecaster's own chance of this, stated with the estimate: 3%); at least 12-fold (1.09 log units) between middle value and limit.
By their numbers in this assay, from the lowest: compound 1; then compound 3; then compound 2. At a limit, above all of these: compound 4.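

In this assay, the saturated chain carbon three bonds along the chain from an oxygen on an aromatic ring proves sensitive to substitution: the group of 5 heavy atoms in place of bromine gives an at least 5.0-fold higher number from compound 3 to compound 4 (0.70 log units; beyond the scatter). Compound 4 stands at a limit and not at a number, the only compound shown to do so: the limit of > 10000 nM in this assay, at which 1 of the 4 values shown sits. The earlier steps shown here all altered the substituent on the aromatic carbon and stayed modest, so they did not show that a change at this other site alone could carry the read-out past the numbers of compounds 1, 2 and 3.

The compounds shown do not separate the contribution of the selenium, the nitrile and the added chain carbons. A longer chain still carrying bromine, or an amine or a carboxylic acid in place of bromine, would bear on that question.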